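This account rests on a few compounds, and the source may have more. Where it says the series, first, only, none or still open, it means among the compounds named here.

Measured in a functional assay on MCF7 cells (Homo sapiens) for antiproliferative activity, read by sulforhodamine B assay, with a stated time of 72 h; on this read-out lower numbers stand for stronger inhibition and higher numbers for weaker inhibition:
- compound 1 `O=C(/C=C/c1csc2ccccc12)c1cc(Br)ccc1O`: 1040 nM
- compound 2 `COc1ccc(O)c(C(=O)/C=C/c2csc3ccccc23)c1`: 750 nM
- compound 3 `CCOc1ccc(O)c(C(=O)/C=C/c2csc3ccccc23)c1`: 7500 nM

Compound 2 sits at the low end of the three, together with compound 1, the step between them being a 1.4-fold lower number from compound 1 to compound 2 (0.14 log units; within the scatter). Compound 3 stands clearly apart in this assay, with a 10-fold higher number from compound 2 to compound 3 (1.00 log units; beyond the scatter).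

Next in the series is compound 4 `COc1ccc(OC)c(C(=O)/C=C/c2csc3ccccc23)c1`. Its difference from compound 2 is methyl in place of hydrogen on an oxygen on an aromatic ring, or hydroxy to methoxy.

Among the compounds with values here, no measured step touches this hydroxy, so the evidence is indirect. Within the data shown here, the closest precedent is the only other added methyl, which sits on a saturated chain carbon bound to an oxygen on an aromatic ring, and that step is a 10-fold higher number from compound 2 to compound 3 (1.00 log units; beyond the scatter). The exchange of bromo for ethoxy points the same way, with a 7.2-fold higher number from compound 1 to compound 3 (0.86 log units; beyond the scatter), whereas the exchange of bromo for methoxy shows no change beyond the scatter. Among the measured compounds shown here, a modest rise in the number is therefore expected, smaller than the one seen for compound 3 and quite uncertain. The expected step is a 2.4-fold higher number from compound 2 to compound 4 (0.38 log units; beyond the scatter).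

For compound 4 the estimate is 1800 nM, with an expected range of 350 nM to 9000 nM.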

Compound 4, half-maximal inhibitory concentration: 5500 nM
For compound 4 the middle estimate is 3.1-fold (0.49 log units) below the measured one, and the stated range covers the measured number.
By their numbers in this assay, from the lowest: compounds 2 and 1 (each within the scatter of the next); then compounds 4 and 3 (each within the scatter of the next).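

Methyl in place of hydrogen on an oxygen on an aromatic ring is the first change at this hydroxy, and in this assay it gives a 7.3-fold higher number from compound 2 to compound 4 (0.87 log units; beyond the scatter), so hydroxy to methoxy is not a neutral exchange here, unlike methoxy in place of bromo on an aromatic carbon, which gives a 1.4-fold lower number from compound 1 to compound 2 (0.14 log units; within the scatter). Compound 2 now has two single methyl additions beside it, the one on this oxygen and the one on a saturated chain carbon bound to an oxygen on an aromatic ring, which gives a 10-fold higher number from compound 2 to compound 3 (1.00 log units; beyond the scatter), and both raise the number beyond the scatter. Nothing at hand explains the rise at this oxygen.

The compounds shown cannot separate the loss of the hydrogen on this oxygen from the gain of the methyl, and an amine or a fluoro group in place of the hydroxy would bear on that question. Also open, going by these compounds, are a longer chain on this oxygen and whether the same change costs as much when bromo replaces the methoxy of compound 2.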